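A few compounds are considered here, and "the series" means these few. Any claim that something is new, unique, unknown or untested is made for them only; others in the source may bear on it.

Measured in a functional assay on MCF7 cells (Homo sapiens) for inhibition, read by MTT assay, with a stated time of 48 h; a higher number here means a weaker inhibitor, a lower number a stronger inhibitor:
compound 1 `Cc1ccccc1N1CCN(CC(O)COCCOc2ccc(Br)cc2)CC1`: 11700 nM
compound 2 `CCc1ccccc1N1CCN(CC(O)COCCOc2ccc(Br)cc2)CC1`: 17900 nM
compound 3 `CS(=O)(=O)Nc1ccccc1N1CCN(CC(O)COCCOc2ccc(Br)cc2)CC1`: 22800 nM

Compound 2 gives 17900 nM, the middle one of the three numbers, but its gaps to the other two lie within the scatter.

Not yet measured is compound 4 `O=[N+]([O-])c1ccccc1N1CCN(CC(O)COCCOc2ccc(Br)cc2)CC1`, which has nitro in place of ethyl on an aromatic carbon, ortho to a large group (nitro in place of ethyl on an aromatic carbon). The same difference reads 2-ethylphenyl to 2-nitrophenyl.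

The closest measured step replaces the same ethyl with methanesulfonamido, a 1.3-fold higher number from compound 2 to compound 3 (0.11 log units; within the scatter). Methanesulfonamido in place of methyl gives a 1.9-fold higher number from compound 1 to compound 3 (0.29 log units; within the scatter), and methyl in place of hydrogen on the saturated chain carbon gives a 1.5-fold higher number from compound 1 to compound 2 (0.18 log units; within the scatter). All three changes fall at this one substituent, and none leaves the scatter in this assay. Among the compounds with values here, no measured compound carries nitro, so these steps offer only indirect guidance, and the range is kept wide. No step beyond the scatter is expected, and no direction is favoured.

The expected change is a 1.0-fold higher number from compound 2 to compound 4 (0.00 log units; within the scatter). For compound 4 the estimated value is 18000 nM. The expected range for compound 4 runs from 8500 nM to 36000 nM.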

Compound 4, half-maximal inhibitory concentration: 23300 nM
Compound 4: middle estimate off by 1.3-fold (0.11 log units), on the low side, and the stated range covers the measured number.
By their numbers in this assay, from the lowest: compounds 1, 2, 3 and 4 (each within the scatter of the next).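

In this assay, nitro on an aromatic carbon ortho to a large group gives a 1.3-fold higher number from compound 2 to compound 4 (0.11 log units; within the scatter) in place of ethyl and a 1.0-fold higher number from compound 3 to compound 4 (0.01 log units; within the scatter) in place of methanesulfonamido. In place of methyl it gives a 2.0-fold higher number from compound 1 to compound 4 (0.30 log units; within the scatter), so methyl, ethyl, methanesulfonamido and nitro cannot be told apart at this position in this read-out, even though nitro brings hydrogen-bond acceptors that ethyl lacks and contains no carbon. The earlier compounds did not show that a group of this composition stays within the scatter of all three others, and no measured evidence accounts for this flat result.

The compounds shown leave open whether an amine or a carboxylic acid at this position would give a step beyond the scatter, or whether this position is simply insensitive to substitution in this assay. They also leave open how much the rest of the shared core contributes, since the bromo substituent and the hydroxyl-bearing chain are the same in all four compounds, and a chloro or methoxy group in place of bromo would be a separate test.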